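This account rests on a few compounds, and the source may have more. Where it says the series, first, only, none or still open, it means among the compounds named here.

Measured so far:
Compound 1 (`COc1ccccc1-c1ncc(C(=O)O)c(=O)[nH]1`): 10 mg/kg
Compound 2 (`CCOC(=O)c1cnc(-c2ccccc2[N+](=O)[O-])[nH]c1=O`): "not determined" (no result reported)

Both compounds were taken into a functional assay on the whole organism (strain Sprague-Dawley) for inhibition, with Rattus norvegicus as the target, with a stated time of 10 min (a higher number here means that more compound is needed for the effect, a lower number that less compound is needed), but only compound 1 has a numerical result. For compound 2 the entry reads "not determined" (no result reported) and gives no single number, so it offers no point of comparison. Still unmeasured is compound 3 (`CCOC(=O)c1cnc(-c2ccccc2OC)[nH]c1=O`). The structural change methoxy in place of nitro on an aromatic carbon places methoxy in place of nitro on an aromatic carbon, ortho to a large group. With no value for compound 2, the size of this step cannot be read from its starting point. Within the data shown here, the only numerical guide is compound 1 at 10 mg/kg, which also carries methoxy but is a carboxylic acid, whereas compound 3 is an ethyl ester. On that single comparison, a moderate step beyond the scatter is expected, toward a higher dose than compound 1 needs, though this expectation is uncertain. Compound 3 is estimated at 25 mg/kg, with an expected range from 5 mg/kg to 100 mg/kg in this measurement.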

Compound 3, dose for 50% inhibition: 10 mg/kg
Compound 3: middle estimate off by 2.5-fold (0.40 log units), on the high side; the range from low to high includes it.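

In this assay, among these compounds, the first readable step at the ester position, ethyl in place of hydrogen on an oxygen next to a carbonyl group, gives no change at the digits printed from compound 1 to compound 3 (within the scatter), which shows that with methoxy on the aromatic carbon, the carboxylic acid of compound 1 and the ethyl ester of compound 3 cannot be told apart in this whole-animal measurement. The change from nitro to methoxy cannot be read, since compound 2 has no number to serve as its starting point, so this result speaks to the ester position and not to the methoxy group. Nothing at hand explains why the ethyl group leaves the dose within the scatter, and no supporting measurement bears on the result.

The compounds shown leave open whether this agreement would extend to a primary amide or to a longer chain such as butyl in place of the ethyl. They also leave open how a hydroxyl group or a chlorine atom in place of methoxy, on that same aromatic carbon, would compare with compound 3 in this assay.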